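A Nitro Group Replaces Bromine on the Benzyl Arm

A few compounds are considered here, and "the series" means these few. Any claim that something is new, unique, unknown or untested is made for them only; others in the source may bear on it.

Three close relatives of one shared core have been tested in an ADME assay on MT4 cells (Homo sapiens) for cytotoxicity, read by MTT assay, with a stated time of 4 days; a lower number here means that less compound is tolerated, a higher number that more compound is tolerated. Compound 1 `CCOC(=O)c1cnc(N2CCN(Cc3cccc(C#N)c3)CC2)nc1Oc1c(C)cc(-c2ccc(C#N)cc2)cc1C` gives only a limit, > 125000 nM. Compound 2 `CCOC(=O)c1cnc(N2CCN(Cc3cccc(C(=O)OC)c3)CC2)nc1Oc1c(C)cc(-c2ccc(C#N)cc2)cc1C` likewise reaches only a limit, > 125000 nM. Compound 3 `CCOC(=O)c1cnc(N2CCN(Cc3ccc(Br)cc3)CC2)nc1Oc1c(C)cc(-c2ccc(C#N)cc2)cc1C` stands at a limit too, > 125000 nM. Because (the limit of > 125000 nM in this assay, at which 3 of the 3 values shown sit), none of the steps among them can be read: the change from compound 1 to compound 2 is a step that the two limits leave unreadable from compound 1 to compound 2, from compound 1 to compound 3 is a step that the two limits leave unreadable from compound 1 to compound 3, and from compound 2 to compound 3 is a step that the two limits leave unreadable from compound 2 to compound 3. Within the data shown here, in plain words, every compound tested so far was tolerated by the cells up to the highest concentration tried, and where compound 3 stands is known only as that limit.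

Compound 4 `CCOC(=O)c1cnc(N2CCN(Cc3ccccc3[N+](=O)[O-])CC2)nc1Oc1c(C)cc(-c2ccc(C#N)cc2)cc1C` differs from compound 3 in one place: 2-nitrophenyl in place of 4-bromophenyl on a saturated chain carbon bound to an amine nitrogen in a ring. The measured steps bear on this change only in that two earlier swaps of the aromatic group on the same saturated chain carbon left the read-out at its limit each time. Among the measured compounds shown here, no step of readable size exists to suggest a direction, so the expectation is for no change beyond the scatter, and the step from compound 3 to compound 4 in this assay is estimated as a number no higher from compound 3 to compound 4 (the limit leaves the size open). Compound 4 is therefore expected to give 125000 nM, within 60000 nM to 250000 nM, most likely again as a limit.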

Compound 4, half-maximal cytotoxic concentration: >= 78700 nM
Compound 4 ended at the assay's limit (the forecaster's own chance of this, stated with the estimate: 80%); the middle value lies beyond the limit too.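

Compound 4 gives only a limit, >= 78700 nM. Among these compounds, compound 1, compound 2 and compound 3 also sit at limits, so no step to compound 4 can be read. With no exact value among these four compounds, this assay leaves open whether changing the aromatic group on the benzyl arm alters how much compound the cells tolerate.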